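Adding a Third Methoxy to a Pyrazolyl Chalcone

The source may report more compounds than this note shows. Statements on the series, on what has been measured and on what is new or still open speak of the compounds shown alone.

Among the measured compounds shown here, compound 1 `COc1ccc(C(=O)/C=C/c2cc(-c3cc(OC)c(OC)c(OC)c3)n[nH]2)cc1OC` is the only compound here with an actual number in a functional assay on MDA-MB-231 cells (Homo sapiens) for inhibition, read by sulforhodamine B assay, with a stated time of 48 h (a higher number here means that more compound is tolerated, a lower number that less compound is tolerated), where compound 1 gives 6320 nM. Compound 2 `COc1ccc(C(=O)/C=C/c2cc(-c3cc(OC)c(OC)c(OC)c3)n[nH]2)cc1` in this assay reaches only a limit of > 100000 nM. The step of an at least 15-fold higher number from compound 1 to compound 2 (1.19 log units; beyond the scatter) therefore rests on the limit of > 100000 nM in this assay, at which 1 of the 2 values shown sits, rather than on a second number. Compound 3 `COc1cc(C(=O)/C=C/c2cc(-c3cc(OC)c(OC)c(OC)c3)n[nH]2)cc(OC)c1OC` differs from compound 1 by methoxy in place of hydrogen on an aromatic carbon. For the measured compounds named here, the one measured step runs the other way, taking a methoxy off and costing a large amount of tolerance; it bears on compound 3 only loosely, since adding a methoxy need not mirror removing one. The expectation is a step in this assay a 1.6-fold lower number from compound 1 to compound 3 (0.20 log units; within the scatter) that is small, plausibly toward a lower number, but not clearly beyond the scatter. Compound 3 is therefore estimated at 4000 nM, with a range from 1500 nM to 15000 nM.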

Compound 3, concentration lethal to 50% of the cells: 9510 nM
For compound 3 the middle estimate is 2.4-fold (0.38 log units) below the measured one; low and high end bracket the measured number.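

Putting methoxy in place of hydrogen on this aromatic carbon, ortho to a methoxy group and meta to a large group, gives a 1.5-fold higher number from compound 1 to compound 3 (0.18 log units; within the scatter) in this assay. Compound 1 and compound 3 therefore cannot be told apart here, so this position takes the added methoxy with no step beyond the scatter. The only step beyond the scatter among the compounds shown remains the one that takes a methoxy away, and it rests on a limit for compound 2: the limit of > 100000 nM in this assay, at which 1 of the 3 values shown sits.

Going by these compounds, whether a hydroxy group, an amine or a fluorine on this same aromatic carbon would also stay within the scatter remains open. So does the effect of a longer chain such as ethoxy in place of the added methoxy, and whether the picture holds beyond this assay.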